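The source may hold more compounds than are shown below. What is called first, only, known or untested is meant among the compounds shown, and "the series" means these compounds.

Of the compounds shown here, three sharing one core have been measured in a functional assay on MCF7 cells (Homo sapiens) for cytotoxicity, read by MTT assay, with a stated time of 48 h; a higher number here means a weaker inhibitor, a lower number a stronger inhibitor. Compound 1 `COc1ccc(CNC(=O)CSc2nc3ccc(NC(=O)c4ccccc4OC)cc3s2)cc1` gives 9300 nM, compound 2 `COc1ccc(CNC(=O)CSc2nc3ccc(NC(=O)c4ccccc4)cc3s2)cc1` gives 21200 nM, and compound 3 `COc1ccc(CNC(=O)CSc2nc3ccc(NC(=O)CCl)cc3s2)cc1` gives 5100 nM. Compound 2 has the highest number of the three: there is a 2.3-fold higher number from compound 1 to compound 2 (0.36 log units; beyond the scatter) and a 4.2-fold lower number from compound 2 to compound 3 (0.62 log units; beyond the scatter), whereas a 1.8-fold lower number from compound 1 to compound 3 (0.26 log units; within the scatter). Compound 4 `O=C(CSc1nc2ccc(NC(=O)c3ccccc3)cc2s1)NCc1ccc(Cl)cc1` has not yet been tested in this assay; it differs from compound 2 in that (chloro in place of methoxy on an aromatic carbon). For the measured compounds named here, none of the measured steps touches that position; all three concern the group on a carbonyl carbon, so they offer no direct guide. Without such a precedent, no step beyond the scatter is expected, and for compound 4 the estimate is 16000 nM, with a range from 6000 nM to 45000 nM, meaning a 1.3-fold lower number from compound 2 to compound 4 (0.12 log units; within the scatter).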

Compound 4, half-maximal inhibitory concentration: 33700 nM
Beside the measured number, compound 4's estimate is 2.1-fold (0.32 log units) below it; the measured number falls inside the stated range.
By their numbers in this assay, from the lowest: compounds 3 and 1 (each within the scatter of the next); then compounds 2 and 4 (each within the scatter of the next).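

In this assay, for the compounds shown here, the exchange of 4-methoxybenzyl for 4-chlorobenzyl gives a 1.6-fold higher number from compound 2 to compound 4 (0.20 log units; within the scatter) and is the first reading at this position, which the earlier steps never touched. With phenyl on the carbonyl carbon, chloro and methoxy on this aromatic carbon cannot be told apart in this assay. Nothing available explains this result. Still open, on these data alone, is whether an amine or a carboxylic acid at this aromatic carbon would give a step beyond the scatter. Also open, as far as these compounds go, is whether chloro and methoxy stay equivalent alongside the chloromethyl group of compound 3.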